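Replacing the Pivalamide by an Acrylamide on the Shared Core

The compounds below may be only part of what the source reports. "The series", "measured", "known", "first", "only" and "open" are said of these compounds alone.

Compound 2 `CC(C)(C)C(=O)Nc1ccc(SCC(=O)Nc2cc(Cl)ccn2)cc1` sits at the edge of a functional assay on A875 cells (Homo sapiens) for antiproliferative activity, read by MTT assay, with a stated time of 48 h; on this read-out higher numbers stand for weaker inhibition and lower numbers for stronger inhibition: for compound 2 the reading > 80000 nM is a limit of this assay and not a number, as the limit of > 80000 nM in this assay, at which 1 of the 2 values shown sits, records. Compound 1 `O=C(CCl)Nc1ccc(SCC(=O)Nc2cc(Cl)ccn2)cc1` gives 850 nM in this assay. Compound 3 `C=CC(=O)Nc1ccc(SCC(=O)Nc2cc(Cl)ccn2)cc1` differs from compound 2 by vinyl in place of tert-butyl on a carbonyl carbon. Because an at least 94-fold higher number from compound 1 to compound 2 (1.97 log units; beyond the scatter) was large when the tert-butyl entered, removing that tert-butyl for a vinyl is expected to bring a large fall, estimated as an at least 53-fold lower number from compound 2 to compound 3 (1.72 log units; beyond the scatter). Compound 3 is therefore expected near 1500 nM, within 300 nM to 20000 nM.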

Compound 3, half-maximal inhibitory concentration: 14700 nM
Compound 3: the middle estimate sits 9.8-fold (0.99 log units) below what was measured; the range from low to high includes it.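

Compound 2 stands at a limit of this assay, not at a number: the limit of > 80000 nM in this assay, at which 1 of the 3 values shown sits. Vinyl on this carbonyl carbon recovers part of the activity, with an at least 5.4-fold lower number from compound 2 to compound 3 (0.73 log units; beyond the scatter) in the same assay. It does not return to the level of the chloromethyl amide, with a 17-fold higher number from compound 1 to compound 3 (1.24 log units; beyond the scatter) here, so removing the tert-butyl alone does not account for the reading of compound 1. The compounds shown leave open how bromomethyl or plain methyl would read on this carbonyl carbon. They also leave open whether a longer chain ending in an amine would be tolerated there.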